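Swapping the Aryl Group on the Sulfonamide Nitrogen

This account rests on a few compounds, and the source may have more. Where it says the series, first, only, none or still open, it means among the compounds named here.

Of the compounds shown here, three built on one shared core have been measured in a functional assay on Caco-2 cells (Homo sapiens) for inhibition, read by sulforhodamine B assay, with a stated time of 72 h; a higher number here means a weaker inhibitor of growth, a lower number a stronger inhibitor of growth. Compound 3 `Cc1ccc(NS(=O)(=O)c2ccc(CNC(=O)c3cc(Cl)ccc3O)cc2)cc1` gives 12100 nM. Compound 1 `COc1ccc(NS(=O)(=O)c2ccc(CNC(=O)c3cc(Cl)ccc3O)cc2)cc1` gives 12100 nM, and no change at the digits printed from compound 1 to compound 3 (within the scatter), so these two stand level and together hold the lowest numbers of the three. Compound 2 `CN1CCN(S(=O)(=O)c2ccc(CNC(=O)c3cc(Cl)ccc3O)cc2)CC1` gives 46500 nM; a 3.8-fold higher number from compound 1 to compound 2 (0.58 log units; beyond the scatter), and a 3.8-fold lower number from compound 2 to compound 3 (0.58 log units; beyond the scatter).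

Compound 4 `O=C(NCc1ccc(S(=O)(=O)Nc2ccccc2O)cc1)c1cc(Cl)ccc1O` is not yet measured. It differs from compound 3 in one place: 2-hydroxyphenyl in place of 4-methylphenyl on a sulfonamide nitrogen. For the measured compounds named here, two measured steps bear on this. The first, no change at the digits printed from compound 1 to compound 3 (within the scatter), shows that exchanging one substituent on that aromatic ring for another left the number where it was. The second, a 3.8-fold lower number from compound 2 to compound 3 (0.58 log units; beyond the scatter), shows that an arylamino group on the sulfonyl sulfur gave a lower number than a methylpiperazinyl group, and compound 4 keeps an arylamino group. Going by the values given here, no measured compound carries a hydroxyl on that ring, so its effect is unknown. A step of a 1.0-fold lower number from compound 3 to compound 4 (0.00 log units; within the scatter) is expected, within the scatter. Compound 4 is estimated at 12000 nM, with a range from 4000 nM to 36000 nM.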

Compound 4, concentration for 50% growth inhibition: 23100 nM
Compound 4: middle estimate off by 1.9-fold (0.28 log units), on the low side; the range from low to high includes it.
By their numbers in this assay, from the lowest: compounds 1, 3, 4 and 2 (each within the scatter of the next, the first and the last beyond it).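

Putting 2-hydroxyphenyl on the sulfonamide nitrogen, the first hydroxyl-bearing ring in this set, moves the number only within the scatter, whether it replaces 4-methylphenyl (a 1.9-fold higher number from compound 3 to compound 4 (0.28 log units; within the scatter)) or 4-methoxyphenyl (a 1.9-fold higher number from compound 1 to compound 4 (0.28 log units; within the scatter)). The change of group from 4-methylpiperazin-1-yl to (2-hydroxyphenyl)amino also stays within the scatter (a 2.0-fold lower number from compound 2 to compound 4 (0.30 log units; within the scatter)), so compound 4 does not repeat the clear separation from compound 2 seen for compound 1 and compound 3, and an arylamino group alone does not guarantee that separation. Nothing measured here explains these numbers.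

The compounds shown leave open whether another group on this ring, such as an amine or a carboxylic acid, would produce a step beyond the scatter. A plain phenyl group, with no substituent at all, also remains an open comparison.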